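Chloro for methyl on two fused cores, in vivo

A few compounds are considered here, and "the series" means these few. Any claim that something is new, unique, unknown or untested is made for them only; others in the source may bear on it.

Measured so far:
compound 1 `O=c1c(-c2nn[nH]n2)c[nH]c2ccc(Cl)cc12` gives > 10 mg/kg in a functional assay on the whole organism (strain Sprague-Dawley) for inhibition, with Rattus norvegicus as the target; a higher number here means that more compound is needed for the effect, a lower number that less compound is needed
compound 2 `Cc1ccc2[nH]cc(-c3nn[nH]n3)c(=O)c2c1` gives 1.25 mg/kg in this assay
compound 3 `Cc1cccc2cc(C(=O)O)cnc12` gives > 50 mg/kg in this assay

The value of compound 1 is a limit, not a number, because the limit of > 10 mg/kg in this assay, at which 1 of the 3 values shown sits, the step of an at least 8.0-fold higher number from compound 2 to compound 1 (0.90 log units; beyond the scatter) is read only as a lower bound. The change behind it is chloro in place of methyl on an aromatic carbon. The value of compound 3 is likewise a limit; the limit of > 50 mg/kg in this assay, at which 1 of the 3 values shown sits, marks where it sits. The difference between the core of compound 2 and the core of compound 3 is not broken down here.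

Compound 4 `O=C(O)c1cnc2c(Cl)cccc2c1` is not yet measured. It carries the same kind of change as compound 1 does, (chloro in place of methyl on an aromatic carbon), with the place now ortho to a fused ring and meta to a fused ring rather than meta to a fused ring and para to a fused ring. Within the data shown here, since compound 3 already sits at a limit, and since the one measured instance of this change raised the number by an at least 8.0-fold higher number from compound 2 to compound 1 (0.90 log units; beyond the scatter), compound 4 is expected to remain at or beyond the limit, a step that the limit leaves unreadable from compound 3 to compound 4. The estimate for compound 4 is 120 mg/kg, between 40 mg/kg and 400 mg/kg.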

Compound 4, minimum effective dose: 25 mg/kg
Compound 4: middle estimate off by 4.8-fold (0.68 log units), on the high side; measured number below the stated range.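

In this assay, chloro in place of methyl does not carry the same result from one core to the other: the same change on two cores in this assay, an at least 8.0-fold higher number (0.90 log units; beyond the scatter) from compound 2 to compound 1 and an at least 2.0-fold lower number (0.30 log units; that floor lies within the scatter) from compound 3 to compound 4, at least 16-fold (1.20 log units) apart, beyond the scatter of two such steps

Taken alone, the new step, an at least 2.0-fold lower number from compound 3 to compound 4 (0.30 log units; that floor lies within the scatter), is only a floor and shows no reliable gain on this core, and the contrast rests on just two pairs, in which the place of the change differs along with the core, so the effect of the core cannot be separated from that of the place. Compound 3 gives > 50 mg/kg, which is a limit and not a number, and the full size of the new step stays unread.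

From the compounds shown here alone, compound 1 gives > 10 mg/kg, also a limit and not a number, and the full size of the step on that core remains open. Also open, going by these compounds, is whether a fluoro, a methoxy or an amine at these places would follow methyl or chloro in this assay on either core.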